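The compounds below may be only part of what the source reports. "The series", "measured", "known", "first", "only" and "open" are said of these compounds alone.

Working notes on the series. Three close analogues have been run in a functional assay on NCI-H522 cells (Homo sapiens) for cytotoxicity, read by sulforhodamine B assay, with a stated time of 48 h; on this read-out higher numbers stand for weaker inhibition of growth and lower numbers for stronger inhibition of growth. Compound 1 `ClCc1ccc(Cn2cnc3c(Cl)ncnc32)cc1` gives 3540 nM. Compound 2 `ClCc1ccccc1Cn1cnc2ncnc(Cl)c21` gives 2810 nM, the lowest of the three numbers, though its gaps to compound 3 and to compound 1 both fall within the usual scatter, so no order can be read from them. Compound 3 `Nc1nc(Cl)c2ncn(Cc3cccc(CCl)c3)c2n1` gives 3310 nM. Against this flat picture stands compound 4 `ClCc1ccccc1Cn1cnc2nc(Cl)nc(Cl)c21`, not yet measured in this assay. It differs from compound 2 in one place: chloro in place of hydrogen on an aromatic carbon. Within the data shown here, no measured pair in the set carries this change, so no step for it is known. The three compounds already measured sit close together despite their differences, which gives no reason to expect a large movement from one more chloro on the core. The step in this assay is therefore expected to stay within the scatter, with no clear direction: a 1.0-fold lower number from compound 2 to compound 4 (0.00 log units; within the scatter). Compound 4 is thus estimated at 2800 nM, with a range from 1000 nM to 8000 nM.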

Compound 4, concentration for 50% growth inhibition: 2950 nM
For compound 4 the middle estimate is 1.1-fold (0.02 log units) below the measured one, within the range that was stated.
By their numbers in this assay, from the lowest: compounds 2, 4, 3 and 1 (each within the scatter of the next).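

In this assay the step of a 1.0-fold higher number from compound 2 to compound 4 (0.02 log units; within the scatter) comes with chloro in place of hydrogen on an aromatic carbon, and this is the only pair shown that isolates the change. At this carbon, between two ring nitrogen atoms, chloro therefore produces no readable shift in the number against compound 2, so the position accepts this one heavy atom without a change beyond the scatter. No independent measurement bears on why the step stays this small.

As far as these compounds go, the step rests on a single pair, so whether the same change behaves alike on compound 1 stays open. From the compounds shown here alone, how a methoxy group, a carboxylic acid or a longer chain would read at this carbon also stays open, since a chloro result does not extend to them.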